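Working notes: the step from compound 3 to compound 4

This account rests on a few compounds, and the source may have more. Where it says the series, first, only, none or still open, it means among the compounds named here.

In an ADME assay on microsomes from liver (Homo sapiens) for metabolic stability, read by LC-MS, using NADPH, tested at 1 uM (a lower number here means that the compound disappears faster, a higher number that the compound lasts longer), compound 1 (`Cc1nc2c(N)ncnc2n1[C@@H]1O[C@H](CN(C)C/C=C\CNC(=O)OCc2ccccc2)[C@@H](O)[C@H]1O`) gives 0.4 h as a measured number. Compound 2 (`Cc1nc2c(N)ncnc2n1[C@@H]1O[C@H](CN(C)C/C=C\CNC(=O)OC(C)C)[C@@H](O)[C@H]1O`) gives > 1.5 h as a limit of the assay. Among the compounds with values here, compound 3 (`CC(=O)NC/C=C\CN(C)C[C@H]1O[C@@H](n2cnc3c(N)ncnc32)[C@H](O)[C@@H]1O`) gives > 1.5 h as a limit too, so compound 3 has no exact number and stands at the limit of > 1.5 h in this assay, at which 2 of the 3 values shown sit, on the values so far.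

Compound 4 (`CCCC(=O)NC/C=C\CN(C)C[C@H]1O[C@@H](n2cnc3c(N)ncnc32)[C@H](O)[C@@H]1O`) differs from compound 3 by ethyl in place of hydrogen on a saturated chain carbon bound to a carbonyl carbon with acetamido becoming (propylcarbonyl)amino.

Within the data shown here, one measured step bears on this, and only indirectly, since it involves isopropyl in place of benzyl on an oxygen next to a carbonyl group. That step is an at least 3.7-fold higher number from compound 1 to compound 2 (0.57 log units; beyond the scatter) and it points to the smaller group giving the longer half-life. A modest move to a lower number, possibly none beyond the scatter, is therefore expected here. The estimated step is an at least 1.1-fold lower number from compound 3 to compound 4 (0.06 log units; that floor lies within the scatter) in this assay for this change. For compound 4 the expected half-life is 1.3 h with an estimated range from 0.5 h to 3 h in this assay.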

Compound 4, half-life: > 1.5 h
Compound 4 gave a limit, no number (the forecaster's own chance of this, stated with the estimate: 50%); middle value at least 1.1-fold (0.06 log units) away from the limit.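

Compound 3 and compound 4 both stand at a limit rather than a number in this assay, so no step can be read between them: the limit of > 1.5 h in this assay, at which 3 of the 4 values shown sit.

The compounds shown leave open whether (propylcarbonyl)amino in place of acetamido changes the half-life at all.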